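A few compounds are considered here, and "the series" means these few. Any claim that something is new, unique, unknown or untested is made for them only; others in the source may bear on it.

Compound 1 `O=C(/C=C/c1ccc2c(c1)B(O)OC2)c1ccc(C(F)(F)F)cc1` gives in an ADME assay on L929 cells (Mus musculus) for cytotoxicity, read by resazurin assay, with a stated time of 72 h (on this read-out lower numbers stand for stronger inhibition and higher numbers for weaker inhibition), a limit of > 10 ug/mL.
Compound 2 `O=C(/C=C/c1ccc2c(c1)B(O)OC2)c1ccc(I)cc1` gives in this assay a limit of > 10 ug/mL.
Compound 3 `COc1ccc(C(=O)/C=C/c2ccc3c(c2)B(O)OC3)cc1OC` gives in this assay a limit of > 10 ug/mL.

Compound 2 stands at the limit of > 10 ug/mL in this assay, at which 3 of the 3 values shown sit, so the step that the two limits leave unreadable from compound 1 to compound 2 cannot be read. Compound 4 `Cc1cccc(C(=O)/C=C/c2ccc3c(c2)B(O)OC3)c1` is not yet measured; it differs from compound 2 in one place: 3-methylphenyl in place of 4-iodophenyl on a carbonyl carbon. Among the compounds with values here, no measured step bears on this change with a readable size, since all three values are limits. Compound 4 is therefore expected to sit at or beyond the same limit, with a step that the limit leaves unreadable from compound 2 to compound 4 that is expected to stay within the scatter. The estimate for compound 4 in this assay is 20 ug/mL, in the range 8 ug/mL to 60 ug/mL.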

Compound 4, half-maximal inhibitory concentration: 8.56 ug/mL
The estimate for compound 4 lay 2.3-fold (0.37 log units) above the measured number; low and high end bracket the measured number.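

With 3-methylphenyl in place of 4-iodophenyl on a carbonyl carbon, this assay shows an at least 1.1-fold lower number from compound 2 to compound 4 (0.06 log units; that floor lies within the scatter). Compound 4 is the only compound shown with a number rather than a limit, so a group at this place can give a readable value, though this floor does not establish a real change, and the other steps cannot be read. Compound 2 itself gives only a limit, as do most compounds shown: the limit of > 10 ug/mL in this assay, at which 3 of the 4 values shown sit.

The compounds shown do not separate the swap of iodine for methyl from the shift in the group's place on the ring. From the compounds shown here alone, whether an amine or a carboxylic acid at this place would also give a number stays open.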